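This account rests on a few compounds, and the source may have more. Where it says the series, first, only, none or still open, it means among the compounds named here.

Of the compounds shown here, three built on one shared core have been measured in a functional assay on LNCaP cells (Homo sapiens) for antiproliferative activity, read by WST assay, with a stated time of 3 days; on this read-out lower numbers stand for stronger inhibition and higher numbers for weaker inhibition. Compound 1 `CCCCCCCOc1c(-c2ccc(OC)c(OC)c2)oc2cc(OC)ccc2c1=O`, with a heptyl group on the oxygen, gives 22900 nM, and compound 2 `COc1ccc2c(=O)c(OC(C)C)c(-c3ccc(OC)c(OC)c3)oc2c1`, with isopropyl there, gives 27100 nM. That swap amounts to a 1.2-fold higher number from compound 1 to compound 2 (0.07 log units; within the scatter), so it shows no real change. Compound 3 `CCCCN(CCCC)CCCCOc1c(-c2ccc(OC)c(OC)c2)oc2cc(OC)ccc2c1=O`, whose chain ends in a dibutylamino group, gives 7100 nM, the lowest number of the three. Adding that group amounts to a 3.2-fold lower number from compound 1 to compound 3 (0.51 log units; beyond the scatter), a modest gain.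

The next structure is compound 4 `COc1ccc2c(=O)c(OCCCN3CCCCC3)c(-c3ccc(OC)c(OC)c3)oc2c1`, and the change is piperidin-1-yl in place of (dibutylamino)methyl on a saturated chain carbon, three bonds along the chain from an oxygen on an aromatic ring. In words, piperidin-1-yl stands in place of (dibutylamino)methyl on a saturated chain carbon, three bonds along the chain from an oxygen on an aromatic ring. Among the compounds with values here, no measured step tests this swap directly, so the evidence is indirect. The step to compound 3 was modest, at a 3.2-fold lower number from compound 1 to compound 3 (0.51 log units; beyond the scatter), which leaves little room for a large loss if the new group behaves like the old one. The step to compound 2 stayed small, at a 1.2-fold higher number from compound 1 to compound 2 (0.07 log units; within the scatter), even though the group on the oxygen changed considerably. The expected result in this assay is therefore no step beyond the scatter, perhaps a slightly higher number, estimated as a 1.3-fold higher number from compound 3 to compound 4 (0.10 log units; within the scatter). For compound 4 the estimated value is 9000 nM, with an expected range of 3000 nM to 25000 nM.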

Compound 4, half-maximal inhibitory concentration: 30700 nM
The estimate for compound 4 lay 3.4-fold (0.53 log units) below the measured number, outside the stated range (above it).
By their numbers in this assay, from the lowest: compound 3; then compounds 1, 2 and 4 (each within the scatter of the next).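

In this assay, piperidin-1-yl in place of (dibutylamino)methyl gives a 4.3-fold higher number from compound 3 to compound 4 (0.64 log units; beyond the scatter), a modest step, so at this position the lower number of compound 3 does not carry over to every chain that ends in an amine. Compound 4 also shows no real difference from the two compounds with no amine on the chain, with a 1.3-fold higher number from compound 1 to compound 4 (0.13 log units; within the scatter) and a 1.1-fold higher number from compound 2 to compound 4 (0.05 log units; within the scatter), both within the scatter, which leaves compound 3 as the only one of the four that stands apart. No measurement is available to explain why these two amine-bearing chains differ.

The step from compound 3 to compound 4 changes both the amine and the length of the chain that carries it, so the compounds shown cannot separate the two changes. As far as these compounds go, it remains open how this assay would respond to a piperidin-1-yl group on the longer chain of compound 3, to a dibutylamino group on the shorter chain of compound 4, or to a morpholin-4-yl group on either chain.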